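The source may hold more compounds than are shown below. What is called first, only, known or untested is meant among the compounds shown, and "the series" means these compounds.

In a functional assay on A549 cells (Homo sapiens) for cytotoxicity, read by MTT assay, with a stated time of 24 h, tested at 40 uM (a higher number here means a weaker effect of the compound at the concentration tested, a lower number a stronger effect), three compounds have been measured:

Compound 1 `CCCOC(=O)CCC(=O)N1CCN(CCCOc2cc3c(Nc4ccc(F)c(Cl)c4)ncnc3cc2OC)CC1` gives 80.9%.
Compound 2 `CCCCOC(=O)CCC(=O)N1CCN(CCCOc2cc3c(Nc4ccc(F)c(Cl)c4)ncnc3cc2OC)CC1` gives 79.1%.
Compound 3 `CCCCCCOC(=O)CCC(=O)N1CCN(CCCOc2cc3c(Nc4ccc(F)c(Cl)c4)ncnc3cc2OC)CC1` gives 74.2%.

Compound 2 stands second highest of these three numbers, with compound 1 nearest and compound 3 furthest; the steps of a number 1.8 percentage points lower from compound 1 to compound 2 (within the scatter) and a number 4.9 percentage points lower from compound 2 to compound 3 (within the scatter) both lie within the scatter. Compound 4 `CCCCCCCCCCCCCCCOC(=O)CCC(=O)N1CCN(CCCOc2cc3c(Nc4ccc(F)c(Cl)c4)ncnc3cc2OC)CC1` differs from compound 2 by undecyl in place of hydrogen on a saturated chain carbon, four bonds along the chain from an oxygen next to a carbonyl group. The measured steps that bear on this change all lengthen the same chain: the two already named, and a number 6.7 percentage points lower from compound 1 to compound 3 (within the scatter). Each is within the scatter, although all three point the same way. Since compound 4 extends this chain much further than any measured compound, the expected step is a number 11.1 percentage points lower from compound 2 to compound 4 (beyond the scatter), a modest but uncertain fall. Compound 4 is therefore estimated at 68%, within a range from 50% to 86%.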

Compound 4, a percentage reported as activity, at one concentration (the size of the read-out at that concentration, not a potency): 85.5%
Compound 4: middle estimate off by 17.5 percentage points, on the low side; the range from low to high includes it.
By their numbers in this assay, from the lowest: compounds 3, 2, 1 and 4 (each within the scatter of the next, the first and the last beyond it).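

In this assay, adding undecyl at this place does not continue the downward direction of the shorter chains: it gives a number 6.4 percentage points higher from compound 2 to compound 4 (within the scatter) and a number 4.6 percentage points higher from compound 1 to compound 4 (within the scatter), both small enough to show that even this much longer chain leaves the read-out close to those of compound 1 and compound 2. Only a number 11.3 percentage points higher from compound 3 to compound 4 (beyond the scatter) clears the scatter, so compound 4 goes against any steady fall with chain length. Nothing shown explains this turn. As far as these compounds go, what an amine or a carboxylic acid would give in place of undecyl remains open.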